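Benzylsulfanyl series: chain extension from compound 2 to compound 3

A few compounds are considered here, and "the series" means these few. Any claim that something is new, unique, unknown or untested is made for them only; others in the source may bear on it.

Measured compounds:
- compound 1, `Cc1cc(N2CC[C@@H](C)[C@@H](N(C)c3ncnc4[nH]ccc34)C2)n2nc(SCc3ccc([N+](=O)[O-])cc3)nc2n1`: 27000 nM
- compound 2, `Cc1cc(N2CC[C@@H](C)[C@@H](N(C)c3ncnc4[nH]ccc34)C2)n2nc(SCc3ccccc3)nc2n1`: 5870 nM

In a functional assay on MGC-803 cells (Homo sapiens) for inhibition, read by MTT assay, with a stated time of 72 h (on this read-out lower numbers stand for stronger inhibition and higher numbers for weaker inhibition), compound 1 gives 27000 nM and compound 2 gives 5870 nM. Among the measured compounds shown here, the one measured step, a 4.6-fold lower number from compound 1 to compound 2 (0.66 log units; beyond the scatter), involves hydrogen in place of nitro on an aromatic carbon. For the measured compounds named here, compound 2 therefore holds the lowest number of the two so far, with compound 1 as its only neighbour.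

Compound 3, `Cc1cc(N2CC[C@@H](C)[C@@H](N(C)c3ncnc4[nH]ccc34)C2)n2nc(SCCCc3ccccc3)nc2n1`, is not yet measured. Relative to compound 2 the difference is phenethyl in place of phenyl on a saturated chain carbon bound to a sulfur. Going by the values given here, no measured step in this set touches the chain between the sulfur and the aromatic ring; the only step known concerns a substituent on that ring, not its distance from the sulfur. Nothing measured here bears directly on the change, so no step beyond the scatter is expected in this assay in either direction.

Compound 3 is estimated at 6000 nM, with a range of 2000 nM to 18000 nM; the expected step is a 1.0-fold higher number from compound 2 to compound 3 (0.01 log units; within the scatter).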

Compound 3, half-maximal inhibitory concentration: > 100000 nM
Compound 3: only a limit was reported; the forecaster's own chance of this, stated with the estimate: 5%; middle value at least 16-fold (1.22 log units) away from the limit.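

Compound 3 stands in this assay at a limit of the assay, not at a number: the limit of > 100000 nM in this assay, at which 1 of the 3 values shown sits.

The earlier compounds shown here showed only that this part of the series responds to a substituent on the aromatic ring; here the ring stays unsubstituted and benzyl gives way to 3-phenylpropyl on the sulfur, with an at least 17-fold higher number from compound 2 to compound 3 (1.23 log units; beyond the scatter). The other comparison, an at least 3.7-fold higher number from compound 1 to compound 3 (0.56 log units; beyond the scatter), places the (3-phenylpropyl)sulfanyl compound past the 4-nitrobenzyl compound, which had held the highest number, so in these three compounds the chain change costs more in this assay than the nitro group does, and benzylsulfanyl remains the compound with the lowest number.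

From the compounds shown here alone, with one chain length beyond benzyl and a limit in place of a number, the true size of this loss and its course with chain length stay open. Going by these compounds, whether a 2-phenylethyl chain on the sulfur, a phenyl ring bound directly to the sulfur, or a chloro or methoxy group on the ring of the 3-phenylpropyl chain would fall nearer compound 2 or compound 3 also stays open.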